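Three Sulfonamides at the Limit and a Naphthyl Successor

This account rests on a few compounds, and the source may have more. Where it says the series, first, only, none or still open, it means among the compounds named here.

Compound 1 (`COc1cc(C)ccc1S(=O)(=O)NC1=NCCN1C(=S)SN1CCn2c1nsc2=S`), compound 2 (`COc1ccc(OC)c(S(=O)(=O)NC2=NCCN2C(=S)SN2CCn3c2nsc3=S)c1`) and compound 3 (`O=S(=O)(NC1=NCCN1C(=S)SN1CCn2c1nsc2=S)c1ccc(Cl)c(Cl)c1`) share one core and differ only in the aryl group on the sulfonyl sulfur. In a functional assay on KYSE-510 cells (Homo sapiens) for antiproliferative activity, read by crystal violet staining, with a stated time of 96 h (on this read-out lower numbers stand for stronger inhibition of growth and higher numbers for weaker inhibition of growth), compound 1 gives >= 20000 nM, which is a limit of the assay rather than a number. Compound 2 in this assay gives >= 20000 nM, again a limit. Compound 3 in this assay gives >= 20000 nM, also a limit. All three values thus sit together, as shown by the limit of >= 20000 nM in this assay, at which 3 of the 3 values shown sit, so compound 3 stands nowhere distinguishable from its two companions. The steps a step that the two limits leave unreadable from compound 1 to compound 2, a step that the two limits leave unreadable from compound 1 to compound 3 and a step that the two limits leave unreadable from compound 2 to compound 3 therefore have no readable size or direction. Compound 4 (`O=S(=O)(NC1=NCCN1C(=S)SN1CCn2c1nsc2=S)c1cccc2ccccc12`) arises from compound 3 by naphthalen-1-yl in place of 3,4-dichlorophenyl on a sulfonyl sulfur. Among the compounds with values here, since no measured step gives a readable size for an exchange of this aryl group, no direction beyond the scatter can be expected in this assay, and the most plausible outcome is that compound 4 also reaches only the limit. Compound 4 is accordingly estimated at 20000 nM, with a range from 8000 nM to 50000 nM. The expected step is a number no higher from compound 3 to compound 4 (the limit leaves the size open).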

Compound 4, concentration for 50% growth inhibition: >= 20000 nM
Compound 4 ended at the assay's limit (the forecaster's own chance of this, stated with the estimate: 75%); the middle value sits exactly at the limit.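

No new step can be read from compound 1, compound 2 or compound 3 to compound 4, because all four values are limits: the limit of >= 20000 nM in this assay, at which 4 of the 4 values shown sit.
The compounds shown leave open what number lies behind each limit, and so whether exchanging the aryl group on the sulfonyl sulfur changes the result in this assay at all.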